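The source may hold more compounds than are shown below. What is called first, only, known or untested is meant among the compounds shown, and "the series" means these compounds.

Values in a functional assay on DU-145 cells (Homo sapiens) for cytotoxicity, read by MTT assay, with a stated time of 24 h; on this read-out higher numbers stand for weaker inhibition and lower numbers for stronger inhibition:

compound 1 `Cc1ccc(/C=C2\CN(C(=S)SCc3cn(Cc4ccc(F)cc4)nn3)C/C(=C\c3ccc(C)cc3)C2=O)cc1` — 38800 nM
compound 2 `Cc1ccc(/C=C2\CN(C(=S)SCc3cn(Cc4ccccc4F)nn3)C/C(=C\c3ccc(C)cc3)C2=O)cc1` — 80000 nM
compound 3 `O=C1/C(=C/c2ccccc2F)CN(C(=S)SCc2cn(Cc3ccccc3F)nn2)C/C1=C\c1ccccc1F` — a limit only, > 80000 nM

Among the measured compounds shown here, the one change measured on both sides is 4-fluorophenyl in place of 2-fluorophenyl on a saturated chain carbon bound to an aromatic nitrogen, which gives a 2.1-fold lower number from compound 2 to compound 1 (0.31 log units; beyond the scatter). How the core of compound 2 differs from the core of compound 3 is not broken down here. Compound 4 `O=C1/C(=C/c2ccccc2F)CN(C(=S)SCc2cn(Cc3ccc(F)cc3)nn2)C/C1=C\c1ccccc1F` differs from compound 3 by 4-fluorophenyl in place of 2-fluorophenyl on a saturated chain carbon bound to an aromatic nitrogen, the same change at the same place as that from compound 2 to compound 1. Because compound 3 sits at the limit of > 80000 nM in this assay, at which 1 of the 3 values shown sits, its starting point is known only as a limit, so the step to compound 4 is expected to resemble the earlier one but cannot be anchored; it is estimated at a number no higher from compound 3 to compound 4 (the limit leaves the size open). Compound 4 is therefore expected near 80000 nM in this assay, with a likely range from 30000 nM to 200000 nM, and a real chance that only a limit is reported again.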

Compound 4, half-maximal inhibitory concentration: 35700 nM
For compound 4 the middle estimate is 2.2-fold (0.35 log units) above the measured one; measured number inside the range.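

In this assay, 4-fluorobenzyl in place of 2-fluorobenzyl gives an at least 2.2-fold lower number from compound 3 to compound 4 (0.35 log units; beyond the scatter), so the change points the same way on the core of compound 4 as on the core of compound 1. Compound 3 stands only as a limit, so the size of the step on that core is not fixed and equal transfer between the two cores is not shown. The two steps compare as follows: the same change on two cores in this assay, a 2.1-fold lower number (0.31 log units; beyond the scatter) from compound 2 to compound 1 and an at least 2.2-fold lower number (0.35 log units; beyond the scatter) from compound 3 to compound 4; the limit leaves it open whether they differ.

From the compounds shown here alone, whether the trend extends to unsubstituted benzyl, 4-chlorobenzyl or a longer chain such as 2-phenylethyl in the same place stays open. Among the compounds shown here, only two cores carry this change, so its behaviour on any further core also stays open.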